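A few compounds are considered here, and "the series" means these few. Any claim that something is new, unique, unknown or untested is made for them only; others in the source may bear on it.

Compound 1, `CCC[C@H](NC(=O)N1C/C(=C\c2ccc(F)cc2)C(=O)/C(=C/c2ccc(F)cc2)C1)B1OC(C)(C)C(C)(C)O1`: 785 nM
Compound 2, `CC1(C)OB([C@H](CCc2ccccc2)NC(=O)N2C/C(=C\c3ccc(F)cc3)C(=O)/C(=C/c3ccc(F)cc3)C2)OC1(C)C`: 1040 nM
Compound 3, `CC(C)(C)[C@H](NC(=O)N1C/C(=C\c2ccc(F)cc2)C(=O)/C(=C/c2ccc(F)cc2)C1)B1OC(C)(C)C(C)(C)O1`: 828 nM

All three were tested in a functional assay on HCT-116 cells (Homo sapiens) for antiproliferative activity, read by MTT assay, with a stated time of 72 h; on this read-out lower numbers stand for stronger inhibition and higher numbers for weaker inhibition. Compound 1 gives the lowest of the three numbers, yet its gaps to the other two are small: the step of a 1.1-fold higher number from compound 1 to compound 3 (0.02 log units; within the scatter) and the step of a 1.3-fold higher number from compound 1 to compound 2 (0.12 log units; within the scatter) both fall within the scatter, as does a 1.3-fold lower number from compound 2 to compound 3 (0.10 log units; within the scatter), so the three compounds cannot be told apart on this read-out. The shared core is untouched in every case; only the group on the carbon bound to the amide-type nitrogen and the boron atom varies.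

Compound 4, `CC[C@H](NC(=O)N1C/C(=C\c2ccc(F)cc2)C(=O)/C(=C/c2ccc(F)cc2)C1)B1OC(C)(C)C(C)(C)O1`, is not yet measured. Compared with compound 1 it differs by hydrogen in place of methyl on a saturated chain carbon, three bonds along the chain from an amide-type nitrogen and a boron atom. For the measured compounds named here, the steps that bear on this change are a 1.3-fold higher number from compound 1 to compound 2 (0.12 log units; within the scatter), which alters the same chain carbon, and a 1.1-fold higher number from compound 1 to compound 3 (0.02 log units; within the scatter), which replaces the whole group at the carbon bound to nitrogen and boron; neither moved the number beyond the scatter. For compound 4, therefore, the expected step is a 1.1-fold higher number from compound 1 to compound 4 (0.03 log units; within the scatter), with no shift beyond the scatter. Compound 4 is estimated at 850 nM, within a range of 400 nM to 1800 nM.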

Compound 4, half-maximal inhibitory concentration: 876 nM
Compound 4: middle estimate off by 1.0-fold (0.01 log units), on the low side, and the stated range covers the measured number.
By their numbers in this assay, from the lowest: compounds 1, 3, 4 and 2 (each within the scatter of the next).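

Going from propyl to ethyl shortens the chain rather than lengthening or branching it, and this also stays within the scatter in this assay (a 1.1-fold higher number from compound 1 to compound 4 (0.05 log units; within the scatter)). Compound 4 likewise cannot be told apart from the two other compounds, with a 1.1-fold higher number from compound 3 to compound 4 (0.02 log units; within the scatter) and a 1.2-fold lower number from compound 2 to compound 4 (0.07 log units; within the scatter). Propyl, ethyl, tert-butyl and phenethyl on the carbon bound to an amide-type nitrogen and a boron atom therefore all give numbers within the scatter of one another, so this read-out shows no preference among these four groups.

From the compounds shown here alone, whether an amine or a carboxylic acid on this chain would also leave the number within the scatter remains open. Nothing measured here explains why these four groups cannot be told apart.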